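A shorter chain on compound 3

A few compounds are considered here, and "the series" means these few. Any claim that something is new, unique, unknown or untested is made for them only; others in the source may bear on it.

In a functional assay on cells (Mast cell, Rattus norvegicus, strain Wistar) for activation, read by fluorescence, with a stated time of 15 min (on this read-out higher numbers stand for an effect only at larger amounts of compound and lower numbers for an effect already at smaller amounts), compound 1 `CCCCCCCCCCCCCCCCCC(=O)OCCOP(=O)(O)OC[C@H](N)C(=O)O` reads > 10000 nM, which is a limit of the assay and not a number. Compound 2 `CCCCCCCCCCCCCCCCCC(=O)OC[C@@H](COP(=O)(O)OC[C@H](N)C(=O)O)OC` gives 5000 nM, whereas compound 3 `CCCCCCCCCCCCCCCCCC(=O)OCCCOP(=O)(O)O[C@H](C)[C@H](N)C(=O)O` gives 100 nM, the lower of these two numbers by a gap beyond the usual scatter. Compound 4 `CCCCCCCCCCCCCCCC(=O)OCCCOP(=O)(O)O[C@H](C)[C@H](N)C(=O)O` departs from compound 3 as follows: hydrogen in place of ethyl on a saturated chain carbon, ten or more bonds along the chain from a carbonyl carbon. For the measured compounds named here, no measured pair isolates this change, so its size remains a judgement. In this assay a modest rise, slightly beyond the scatter, is expected, with an estimated 2.5-fold higher number from compound 3 to compound 4 (0.40 log units; beyond the scatter). For compound 4 the estimate is 250 nM, with an expected range of 80 nM to 800 nM.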

Compound 4, half-maximal effective concentration: 60 nM
For compound 4 the middle estimate is 4.2-fold (0.62 log units) above the measured one; the measured number lies below the stated range.
By their numbers in this assay, from the lowest: compounds 4 and 3 (each within the scatter of the next); then compound 2. At a limit, above all of these: compound 1.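

In this assay the swap of ethyl for hydrogen on a saturated chain carbon gives a 1.7-fold lower number from compound 3 to compound 4 (0.22 log units; within the scatter) and so leaves the read-out within the scatter. For the compounds shown here, this is the first measured pair that differs in one place, and it shows that the shorter chain of compound 4 keeps the read-out of compound 3. Nothing among the facts given accounts for this result.

Going by these compounds, whether a still shorter chain, a longer chain or a chain ending in an amine or a carboxylic acid would do the same remains open.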